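Swapping an alkenyl chain for an amide on a piperazine

A few compounds are considered here, and "the series" means these few. Any claim that something is new, unique, unknown or untested is made for them only; others in the source may bear on it.

Three compounds share a core built around a hydroxy-ketone bearing a phenyl ring and a small carbocycle, joined to a piperazine. Compound 1 `C=CCN1CCN(CC(=O)C(O)(c2ccccc2)C2CCCCC2)CC1` and compound 2 `CC(C)=CCN1CCN(CC(=O)C(O)(c2ccccc2)C2CCC2)CC1` were examined in a functional assay on ileum for antagonist activity at muscarinic acetylcholine receptor M3 (Cavia porcellus) (on this read-out higher numbers stand for weaker inhibition and lower numbers for stronger inhibition), where compound 1 gives 25.6 nM and compound 2 gives 22 nM; these two numbers lie within the usual scatter of each other, so neither can be ranked ahead of the other. Compound 3 `O=C(CN1CCN(C(c2ccccc2)c2ccccc2)CC1)C(O)(c1ccccc1)C1CCC1` reaches only the limit of the assay, > 10000 nM, which is not a number. Compound 4 `O=C(CN1CCN(CC(=O)C(O)(c2ccccc2)C2CCC2)CC1)N1CCCC1` has not yet been measured. It differs from compound 2 by (pyrrolidin-1-yl)carbonyl in place of 2-methylprop-1-en-1-yl on a saturated chain carbon bound to an amine nitrogen in a ring. For the measured compounds named here, no measured pair shows this kind of change, so the step is an expectation: a modest loss of inhibition is expected, a 4.1-fold higher number from compound 2 to compound 4 (0.61 log units; beyond the scatter), giving compound 4 an estimated 90 nM, with a plausible range from 25 nM to 400 nM.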

Compound 4, antagonist equilibrium constant: 210 nM
Estimate against measurement, compound 4: 2.3-fold (0.37 log units) below; the range from low to high includes it.
By their numbers in this assay, from the lowest: compounds 2 and 1 (each within the scatter of the next); then compound 4. At a limit, above all of these: compound 3.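

In this assay, putting (pyrrolidin-1-yl)carbonyl in place of 2-methylprop-1-en-1-yl gives a 9.5-fold higher number from compound 2 to compound 4 (0.98 log units; beyond the scatter), so inhibition does depend on the group carried at this place. The loss is partial: compound 4 gives 210 nM and remains a measurable inhibitor. Nothing measured here explains the loss of inhibition.

The compounds shown cannot separate the effect of the carbonyl from that of the pyrrolidine ring in this change. A 2-(pyrrolidin-1-yl)ethyl chain, an amine with no carbonyl, at the same place would help to tell them apart.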